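Swapping the phenol ring partners in a hydrazone urea series

A few compounds are considered here, and "the series" means these few. Any claim that something is new, unique, unknown or untested is made for them only; others in the source may bear on it.

Among the measured compounds shown here, compound 2 `COc1cc(/C=N/NC(=O)Nc2ccc(Oc3ccnc(-c4nncn4CCN(C)C)c3)c(F)c2)ccc1O` gives 3780 nM in a functional assay on MKN-45 cells (Homo sapiens) for cytotoxicity, read by MTT assay, with a stated time of 72 h (a lower number here means a stronger inhibitor, a higher number a weaker inhibitor), the lower of the two numbers so far, although its only neighbour, compound 1 `CN(C)CCn1cnnc1-c1cc(Oc2ccc(NC(=O)N/N=C/c3cc(Br)c(O)c(Br)c3)cc2F)ccn1`, gives 4320 nM and the gap is within the scatter. The single difference between them is the step of a 1.1-fold lower number from compound 1 to compound 2 (0.06 log units; within the scatter): a 4-hydroxy-3-methoxyphenyl took the place of a 3,5-dibromo-4-hydroxyphenyl on the carbon double-bonded to nitrogen, and the number hardly moved. Compound 3 `Cc1cc(/C=N/NC(=O)Nc2ccc(Oc3ccnc(-c4nncn4CCN(C)C)c3)c(F)c2)cc(C)c1O` changes the same place once more: 4-hydroxy-3,5-dimethylphenyl in place of 4-hydroxy-3-methoxyphenyl on a carbon with a double bond to nitrogen. For the measured compounds named here, only that one earlier step bears on this change, and it was small. Compound 3 is therefore estimated at 3600 nM because a 1.1-fold lower number from compound 1 to compound 2 (0.06 log units; within the scatter) showed that replacing this ring left the number essentially unchanged. The likely range for compound 3 runs from 1500 nM to 8500 nM. The expected step is a 1.1-fold lower number from compound 2 to compound 3 (0.02 log units; within the scatter), nothing beyond the scatter.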

Compound 3, half-maximal inhibitory concentration: 1510 nM
Beside the measured number, compound 3's estimate is 2.4-fold (0.38 log units) above it; low and high end bracket the measured number.
By their numbers in this assay, from the lowest: compound 3; then compounds 2 and 1 (each within the scatter of the next).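

The first pair suggested that this ring could change with little effect, but that no longer holds. In this assay, 4-hydroxy-3,5-dimethylphenyl on the carbon with a double bond to nitrogen gives a 2.5-fold lower number from compound 2 to compound 3 (0.40 log units; beyond the scatter) and also a 2.9-fold lower number from compound 1 to compound 3 (0.46 log units; beyond the scatter) even though the entering ring has the same count of heavy atoms as 4-hydroxy-3-methoxyphenyl. No measurement here accounts for the lower number of compound 3.

All three rings shown keep the 4-hydroxy group, so the effect of an amine in its place remains open. It is also unknown whether one methyl group would give the same result as two, or how two ethyl groups would compare.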